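A few compounds are considered here, and "the series" means these few. Any claim that something is new, unique, unknown or untested is made for them only; others in the source may bear on it.

Measured compounds:
- compound 1, `CCCS(=O)(=O)Nc1ccc(F)c(C(=O)c2n[nH]c3ncc(-c4ccc(N)cc4)cc23)c1F`: 0.1%
- compound 2, `CCCS(=O)(=O)Nc1ccc(F)c(C(=O)c2n[nH]c3ncc(-c4ccc(Cl)c(C(F)(F)F)c4)cc23)c1F`: 15%

In an assay for binding affinity to dual specificity mitogen-activated protein kinase kinase 4 (Homo sapiens), read by KINOMEscan, tested at 100 nM (on this read-out lower numbers stand for a stronger effect and higher numbers for a weaker effect at the one concentration tested), compound 1 gives 0.1%, the lowest of the two numbers and therefore the strongest effect seen here. Its nearest neighbour is compound 2, reached by a number 14.9 percentage points higher from compound 1 to compound 2 (beyond the scatter), a change that alters the aryl group on the shared core rather than the sulfonamide end.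

Compound 3, `Nc1ccc(-c2cnc3[nH]nc(C(=O)c4c(F)ccc(NS(=O)(=O)Cc5ccccc5)c4F)c3c2)cc1`, differs from compound 1 at that other end: phenyl in place of ethyl on a saturated chain carbon bound to a sulfonyl sulfur. Going by the values given here, no measured step touches this part of the molecule; the only step available, from compound 1 to compound 2, concerns a different position and so gives no direct guide. With compound 1 already near the floor of the read-out, the number can hardly fall further. The step of a number 0.9 percentage points higher from compound 1 to compound 3 (within the scatter) is therefore expected to stay within the scatter, and compound 3 is estimated at 1%, with a range from 0.1% to 8%.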

Compound 3, a percentage reported as activity, at one concentration (the size of the read-out at that concentration, not a potency): 0.1%
For compound 3 the middle estimate is 0.9 percentage points above the measured one; the measured number falls inside the stated range.
By their numbers in this assay, from the lowest: compounds 1 and 3 (each within the scatter of the next); then compound 2.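

In this assay the sulfonamide end now has a measured step: phenyl in place of ethyl on a saturated chain carbon bound to a sulfonyl sulfur gives no change at the digits printed from compound 1 to compound 3 (within the scatter) and so leaves the number where it was. With the 4-aminophenyl group kept, this position therefore accepts the six heavy atoms and aromatic ring of phenyl in place of the two heavy atoms of ethyl, with no visible loss, although both compounds sit so near the floor of the read-out that any gain could not show. Nothing measured here explains this result.

Going by these compounds, whether benzyl is accepted as well alongside the 4-chloro-3-(trifluoromethyl)phenyl group of compound 2, where the number has room to move, remains open. So does the effect of an amine, a carboxylic acid or a longer chain such as hexyl at the sulfonyl end.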